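Para-bromophenyl triazole chalcone: expected potency from measured analogues

A few compounds are considered here, and "the series" means these few. Any claim that something is new, unique, unknown or untested is made for them only; others in the source may bear on it.

Three analogues sharing one core have been measured in a functional assay on RAW264.7 cells (Mus musculus) for inhibition, with a stated time of 4 days; a lower number here means a stronger inhibitor, a higher number a weaker inhibitor. Compound 1 `C=C(C)c1cn(-c2cccc(C(=O)/C=C/c3ccc(O)c(OC)c3)c2)nn1` gives 9790 nM in this assay. Compound 2 `COc1cc(/C=C/C(=O)c2cccc(-n3cc(-c4ccc(F)cc4)nn3)c2)ccc1O` gives 6450 nM in this assay, and compound 3 `COc1cc(/C=C/C(=O)c2cccc(-n3cc(-c4cccc(Cl)c4)nn3)c2)ccc1O` gives 14300 nM in this assay. Compound 3 therefore carries the highest number of the three; its nearest neighbour is compound 1, the step of a 1.5-fold higher number from compound 1 to compound 3 (0.16 log units; within the scatter) lying within the scatter, while the step of a 2.2-fold higher number from compound 2 to compound 3 (0.35 log units; beyond the scatter) reaches beyond it.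

Compound 4 `COc1cc(/C=C/C(=O)c2cccc(-n3cc(-c4ccc(Br)cc4)nn3)c2)ccc1O` has not yet been measured. It differs from compound 3 in one place: 4-bromophenyl in place of 3-chlorophenyl on an aromatic carbon. The step that bears most directly on this change is a 2.2-fold higher number from compound 2 to compound 3 (0.35 log units; beyond the scatter), where a 4-fluorophenyl group gave the lower number; the step of a 1.5-fold lower number from compound 1 to compound 2 (0.18 log units; within the scatter) points the same way but stays within the scatter. Compound 4 is therefore expected to return toward the number of compound 2, and the estimated step of a 1.8-fold lower number from compound 3 to compound 4 (0.25 log units; within the scatter) is a modest decrease in this assay. On that basis compound 4 is estimated to give 8000 nM in this assay, with a likely range from 3500 nM to 18000 nM.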

Compound 4, half-maximal inhibitory concentration: 19100 nM
For compound 4 the middle estimate is 2.4-fold (0.38 log units) below the measured one; the measured number lies above the stated range.
By their numbers in this assay, from the lowest: compounds 2, 1, 3 and 4 (each within the scatter of the next, the first and the last beyond it).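

Exchanging one halogen for another on the phenyl group at this triazole carbon is not neutral in this assay: bromo in place of fluoro gives the largest step among these compounds (a 3.0-fold higher number from compound 2 to compound 4 (0.47 log units; beyond the scatter)), beyond the scatter, so the lower number of compound 2 does not carry over to its 4-bromophenyl analogue. The other two new steps stay within the scatter, so 4-bromophenyl cannot be told apart from 3-chlorophenyl (a 1.3-fold higher number from compound 3 to compound 4 (0.13 log units; within the scatter)), even though the halogen and its place on the phenyl ring both change, or from 1-methylethenyl (a 2.0-fold higher number from compound 1 to compound 4 (0.29 log units; within the scatter)), and among these compounds only the pair of compound 2 and compound 4 is separated by the fluoro-to-bromo exchange. Nothing available here explains why the bromo and fluoro compounds differ.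

The compounds shown leave open whether the identity of the halogen or its place on the phenyl ring governs the number, since a 4-chlorophenyl or 3-bromophenyl group would be needed to separate the two. They also leave open how an unsubstituted phenyl, an amine or a carboxylic acid on that ring would compare with the halogens.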